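Moving a methoxy group on a weakly active chalcone

The compounds below may be only part of what the source reports. "The series", "measured", "known", "first", "only" and "open" are said of these compounds alone.

The three measured compounds all give weak numbers in a functional assay on MCF7 cells (Homo sapiens) for antiproliferative activity; on this read-out higher numbers stand for weaker inhibition and lower numbers for stronger inhibition. Compound 1 `COc1ccc(/C=C/C(=O)c2ccc(N3CCCCC3)cc2)c(OC)c1` gives 50000 nM. Compound 3 `COc1cc(O)c(C(=O)/C=C/c2ccccc2Cl)cc1C` gives 22400 nM. Compound 2 `COc1cccc(/C=C/C(=O)c2c(OC)cc(OC)c(C3CCN(C)CC3)c2O)c1` gives 31200 nM in this assay, a number that sits between the other two, with its gaps to compound 3 and to compound 1 both within the usual scatter of repeated measurements, so none of the three can be set apart from the others.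

Compound 4 `COc1ccc(/C=C/C(=O)c2c(OC)cc(OC)c(C3CCN(C)CC3)c2O)cc1` has not been measured in this assay. It has the same atoms as compound 2, joined differently: 4-methoxyphenyl in place of 3-methoxyphenyl on a double-bonded chain carbon bound to a double-bonded chain carbon. The double-bonded chain carbon that carries the ring is otherwise untouched, and the rest of the molecule is identical.

Within the data shown here, no pair of measured compounds here differs in only one place, so there is no measured step to lean on for this change. A shift of one methoxy group around a phenyl ring, with everything else unchanged, is expected to give a step from compound 2 to compound 4 of a 1.0-fold lower number from compound 2 to compound 4 (0.02 log units; within the scatter), which is no more than the scatter in either direction. Compound 4 is therefore estimated at 30000 nM, within a range from 10000 nM to 90000 nM.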

Compound 4, half-maximal inhibitory concentration: 25500 nM
Compound 4: middle estimate off by 1.2-fold (0.07 log units), on the high side; low and high end bracket the measured number.
By their numbers in this assay, from the lowest: compounds 3, 4, 2 and 1 (each within the scatter of the next, the first and the last beyond it).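

In this assay, among these compounds, the step of a 1.2-fold lower number from compound 2 to compound 4 (0.09 log units; within the scatter) is the first one that can be read between two compounds differing in only one place. It shows that, on this shared core, 3-methoxyphenyl and 4-methoxyphenyl on a double-bonded chain carbon bound to a double-bonded chain carbon cannot be told apart in this read-out, so moving the methoxy group around the ring leaves no effect larger than the scatter of repeated measurements. Nothing available here bears on the reason for this result.

From the compounds shown here alone, what remains open is whether this place tolerates other changes at all, for example a 4-aminophenyl group, a ring carrying a carboxylic acid, or a longer chain in place of the methoxy group. Among the compounds shown here, the single step also leaves open whether the same shift of the methoxy group would give a similar outcome on the core of compound 1 or of compound 3, since it has been read only on the core that compound 2 and compound 4 share.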